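The compounds below may be only part of what the source reports. "The series", "measured", "known", "first", "only" and "open" are said of these compounds alone.

Measured so far:
compound 1, `N#Cc1cc(NCc2ccccc2[N+](=O)[O-])c2cn[nH]c2c1`: 22%
compound 2, `O=[N+]([O-])c1cc(Br)c(F)cc1CNc1cc(C(F)(F)F)cc2[nH]ncc12`: 85%

In an assay for inhibition of Tryptophan 2,3-dioxygenase (Homo sapiens), with stated times of 10 min and 60 min, tested at 10 uM (on this read-out higher numbers stand for a stronger effect at the one concentration tested and lower numbers for a weaker effect), compound 1 gives 22%, the lowest of the two numbers. The nearest number is that of compound 2, which in this assay gives 85%, a gap that lies beyond the usual scatter; the two differ at several places, so that gap is not a single step.

Compound 3, `O=[N+]([O-])c1ccccc1CNc1cc(Br)cc2[nH]ncc12`, has not yet been measured. It differs from compound 1 in one place: bromo in place of cyano on an aromatic carbon. For the measured compounds named here, no pair of measured compounds shows this change alone, and compound 2 carries a bromo on a different ring together with other changes, so nothing measured tells the size of this step.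

In this assay compound 3 is expected to give around 38%, likely between 15% and 65%. The step from compound 1 expected here, a number 16 percentage points higher from compound 1 to compound 3 (beyond the scatter), is estimated as a modest rise that may not exceed the scatter.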

Compound 3, a percentage reported as inhibition, at one concentration (the size of the read-out at that concentration, not a potency): 52%
Compound 3: middle estimate off by 14 percentage points, on the low side; measured number inside the range.
By their numbers in this assay, from the lowest: compound 1; then compound 3; then compound 2.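

In this assay, bromo in place of cyano on this aromatic carbon gives a number 30 percentage points higher from compound 1 to compound 3 (beyond the scatter), so a change at this one place is enough to move the read-out beyond the scatter. For the compounds shown here, this is the first comparison here that isolates a single change, whereas compound 1 and compound 2 differ at several places. No measurement available here bears on why this step occurs.

The compounds shown leave open how other groups on this carbon, such as an amine, a carboxylic acid or a longer alkyl chain, would compare with bromo and cyano in this assay. They also leave open whether the step from cyano to bromo would keep its size with further groups on the other ring, such as those carried by compound 2.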